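Cytotoxicity notes: aryl swap on the chain carbon

The compounds below may be only part of what the source reports. "The series", "measured", "known", "first", "only" and "open" are said of these compounds alone.

Measured so far in an ADME assay on A549 cells (Homo sapiens) for cytotoxicity, read by resazurin assay, with a stated time of 48 h (on this read-out higher numbers stand for lower toxicity in this test and lower numbers for higher toxicity in this test), are:
- compound 1 `O=C(Nc1ccc(NCC2CC2)cc1Cl)c1cc(Cl)ccc1O` with 14400 nM
- compound 2 `O=C(Nc1ccc(NCc2cccc(C(F)(F)F)c2)cc1Cl)c1cc(Cl)ccc1O` with 13300 nM

Compound 2 stands within the scatter of compound 1, so the two cannot be ranked. Compound 3 `CN(C)c1ccc(CNc2ccc(NC(=O)c3cc(Cl)ccc3O)c(Cl)c2)cc1` carries 4-(dimethylamino)phenyl in place of 3-(trifluoromethyl)phenyl on a saturated chain carbon bound to a nitrogen on an aromatic ring. Going by the values given here, the counted difference 4-(dimethylamino)phenyl in place of 3-(trifluoromethyl)phenyl on a saturated chain carbon bound to a nitrogen on an aromatic ring is the only change. Among the compounds with values here, the one measured step at this place is a 1.1-fold lower number from compound 1 to compound 2 (0.03 log units; within the scatter) and it brought in 3-(trifluoromethyl)phenyl in place of cyclopropyl. Within the data shown here, that single step is thin ground, and no measured compound carries 4-(dimethylamino)phenyl. No step beyond the scatter is therefore expected in this assay here. The expected move is a 1.1-fold lower number from compound 2 to compound 3 (0.04 log units; within the scatter) and nothing larger. For compound 3 the estimate is 12000 nM with an expected range from 5500 nM to 25000 nM on repeat measurement.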

Compound 3, half-maximal cytotoxic concentration: 24500 nM
Compound 3: the middle estimate sits 2.0-fold (0.31 log units) below what was measured; the range from low to high includes it.
By their numbers in this assay, from the lowest: compounds 2, 1 and 3 (each within the scatter of the next).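

In this assay the new aromatic group also gives no step beyond the scatter: the change brings a 1.8-fold higher number from compound 2 to compound 3 (0.27 log units; within the scatter) and, set against the small ring, a 1.7-fold higher number from compound 1 to compound 3 (0.23 log units; within the scatter). Cyclopropyl, 3-(trifluoromethyl)phenyl and 4-(dimethylamino)phenyl on this saturated chain carbon therefore cannot be ranked, and the exchange of three fluorine atoms for a nitrogen that counts as a hydrogen-bond acceptor produces no readable difference among these three compounds. No measured information bears on this result.

Open, on these data alone, is whether a carboxylic acid, a primary amine or a longer alkyl chain on this chain carbon would give a step beyond the scatter. All three compounds share the rest of the core, so the compounds shown say nothing about what a change elsewhere in it would do.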